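A few compounds are considered here, and "the series" means these few. Any claim that something is new, unique, unknown or untested is made for them only; others in the source may bear on it.

Compounds measured so far:

- compound 1 `COC(=O)c1nc(C)n(-c2ccc(F)cc2)n1` — 15200 nM
- compound 2 `CCc1nc(C(=O)OC)nn1-c1ccc(F)cc1` — 15800 nM
- compound 3 `COC(=O)c1nc(C2CC2)n(-c2ccc(F)cc2)n1` — 95900 nM

All three share one core and differ only in the group on the aromatic carbon that sits between the two ring nitrogen atoms. In a functional assay on NPC-TW01 cells (Homo sapiens) for inhibition, read by MTT assay, with a stated time of 72 h (a higher number here means a weaker inhibitor of growth, a lower number a stronger inhibitor of growth), compound 3 gives the highest of the three numbers: its nearest neighbour is compound 2, with a 6.1-fold higher number from compound 2 to compound 3 (0.78 log units; beyond the scatter), and the next is compound 1, with a 6.3-fold higher number from compound 1 to compound 3 (0.80 log units; beyond the scatter). Compound 4 `COC(=O)c1nc(C2CCCCC2)n(-c2ccc(F)cc2)n1` is the next step along the same path: cyclohexyl in place of cyclopropyl on an aromatic carbon.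

Two kinds of step are known here. Lengthening the chain, a 1.0-fold higher number from compound 1 to compound 2 (0.02 log units; within the scatter), changed nothing beyond the scatter, whereas closing it into a small ring, a 6.3-fold higher number from compound 1 to compound 3 (0.80 log units; beyond the scatter) and a 6.1-fold higher number from compound 2 to compound 3 (0.78 log units; beyond the scatter), weakened growth inhibition modestly. Replacing the small ring by a larger one has no direct precedent among these compounds, so the expectation is drawn loosely from the ring steps: compound 4 is expected to be, if anything, a somewhat weaker inhibitor than compound 3, a step of a 1.6-fold higher number from compound 3 to compound 4 (0.19 log units; within the scatter). The estimate for compound 4 in this assay is 150000 nM, within a range of 40000 nM to 500000 nM.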

Compound 4, concentration for 50% growth inhibition: 30500 nM
Compound 4: the middle estimate sits 4.9-fold (0.69 log units) above what was measured; measured number below the stated range.
By their numbers in this assay, from the lowest: compounds 1, 2 and 4 (each within the scatter of the next); then compound 3.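

At this aromatic carbon, ring size matters: replacing cyclopropyl with cyclohexyl gives a 3.1-fold lower number from compound 3 to compound 4 (0.50 log units; beyond the scatter) in this assay, so the weakening seen earlier does not come with every carbon ring. The larger ring is not separated from either open chain, with a 1.9-fold higher number from compound 2 to compound 4 (0.29 log units; within the scatter) and a 2.0-fold higher number from compound 1 to compound 4 (0.30 log units; within the scatter), both within the scatter, so among these four compounds only compound 3 stands apart. No evidence here explains why the smaller ring differs from the larger one.

The compounds shown leave open how a cyclobutyl or cyclopentyl ring would compare, and so whether the change with ring size is gradual or peculiar to cyclopropyl. They also leave open how a phenyl ring or an amine would behave here, since every group so far contains only carbon and hydrogen.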